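Compound 4: Swapping the Group on the Ester

The compounds below may be only part of what the source reports. "The series", "measured", "known", "first", "only" and "open" are said of these compounds alone.

Compound 1 `C#Cc1cccc(Nc2ncnc3cc(OCCOC(=O)C(C)c4ccc(CC(C)C)cc4)c(OCCOC)cc23)c1` measures 400 nM
Compound 2 `C#Cc1cccc(Nc2ncnc3cc(OCCOC)c(OCCOC(=O)c4ccccc4OC(C)=O)cc23)c1` measures 100 nM
Compound 3 `C#Cc1cccc(Nc2ncnc3cc(OCCOC)c(OCCOC(=O)C(C)c4ccc(CC(C)C)cc4)cc23)c1` measures > 10000 nM as a limit of the assay

All three compounds were tested in a functional assay on HCC827 cells (Homo sapiens) for antiproliferative activity, read by CCK-8 assay, with a stated time of 72 h (a lower number here means a stronger inhibitor, a higher number a weaker inhibitor), and share one core. For compound 3 the record shows only a limit (the limit of > 10000 nM in this assay, at which 1 of the 3 values shown sits) and no exact number.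

Compound 4 `C#Cc1cccc(Nc2ncnc3cc(OCCOC)c(OCCOC(=O)C(C)c4ccc5cc(OC)ccc5c4)cc23)c1` is built from compound 3 by a single change: 6-methoxynaphthalen-2-yl in place of 4-isobutylphenyl on a saturated chain carbon bound to a carbonyl carbon and a saturated chain carbon and the rest of the structure stays the same. In plain terms, 6-methoxynaphthalen-2-yl replaces 4-isobutylphenyl on a saturated chain carbon bound to a carbonyl carbon and a saturated chain carbon.

Among the measured compounds shown here, only one measured step bears on this change. It is large and beyond the scatter: an at least 100-fold higher number from compound 2 to compound 3 (2.00 log units; beyond the scatter) and it too alters what sits on a carbonyl carbon. Because of an at least 100-fold higher number from compound 2 to compound 3 (2.00 log units; beyond the scatter) the group in this part of compound 4 is expected to matter in this assay and a move toward a lower number is expected. Compound 3 gives only a starting limit, so the size of that move is uncertain, and the result could also stay at the limit. The estimated change is an at least 3.3-fold lower number from compound 3 to compound 4 (0.52 log units; beyond the scatter) and it is expected to be smaller than the measured step. Compound 4 is expected at 3000 nM within an estimated range of 600 nM to 10000 nM in this assay when measured.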

Compound 4, half-maximal inhibitory concentration: 500 nM
The estimate for compound 4 lay 6.0-fold (0.78 log units) above the measured number, and the stated range ends above it.
By their numbers in this assay, from the lowest: compound 2; then compounds 1 and 4 (each within the scatter of the next). At a limit, above all of these: compound 3.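

With all else held fixed, putting 6-methoxynaphthalen-2-yl in place of 4-isobutylphenyl on the saturated chain carbon bound to a carbonyl carbon gives an at least 20-fold lower number from compound 3 to compound 4 (1.30 log units; beyond the scatter) in this assay. The earlier step replaced the whole group on the carbonyl carbon, so it could not tell whether any group built on that saturated chain carbon would end at the limit; this step keeps that carbon and changes only the aromatic group on it, and that change alone is enough to restore a measurable number. The true size of the step remains unknown, because compound 3 stands at a limit of the assay and has no exact number: the limit of > 10000 nM in this assay, at which 1 of the 4 values shown sits.

The change adds a second aromatic ring and a methoxy oxygen at once, so the compounds shown cannot say which of the two accounts for the step. Among the compounds shown here, a plain naphthalen-2-yl group, without the methoxy, or a 4-methoxyphenyl group, with the methoxy but only one ring, on the same carbon would separate the two.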